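A few compounds are considered here, and "the series" means these few. Any claim that something is new, unique, unknown or untested is made for them only; others in the source may bear on it.

Compounds measured so far:
Compound 1 `COc1ccc(Cl)c(-c2nnc3sc(Cc4c[nH]c5ccc(OC)cc45)nn23)c1`: 14.4%
Compound 2 `COc1ccc2[nH]cc(Cc3nn4c(-c5ccoc5C)nnc4s3)c2c1`: 20.1%
Compound 3 `COc1ccc(Cl)c(-c2nnc3sc(Cc4c[nH]c5ccccc45)nn23)c1`: 16.5%

In a functional assay on the whole organism (strain Wistar Albino) for inhibition, with Rattus norvegicus as the target, read by paw edema, with a stated time of 2 h, at a dose of 20 mg/kg (a higher number here means more inhibition at the dose given (going by the name of the read-out), a lower number less inhibition), compound 1 gives 14.4%, compound 2 gives 20.1% and compound 3 gives 16.5%. Going by the values given here, compound 3 stands among three numbers that all lie within the scatter of one another: its closest neighbour is compound 1, with a number 2.1 percentage points higher from compound 1 to compound 3 (within the scatter), and compound 2, for which no single-point step to compound 3 is given, shows a number only a little apart from that of compound 3.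

Compound 4 `Cc1occc1-c1nnc2sc(Cc3c[nH]c4ccccc34)nn12` has not yet been measured in this assay. It differs from compound 3 in one place: 2-methylfuran-3-yl in place of 2-chloro-5-methoxyphenyl on an aromatic carbon. The same exchange has been made once before, on compound 1, and there it gave a number 5.7 percentage points higher from compound 1 to compound 2 (within the scatter), a step within the scatter. On that single precedent no step beyond the scatter is expected from compound 3 to compound 4, and the estimate for compound 4 is 21%, between 11% and 31%, which corresponds to an expected a number 4.5 percentage points higher from compound 3 to compound 4 (within the scatter).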

Compound 4, a percentage reported as inhibition, in the whole organism at one dose (the size of the read-out at that dose, not a potency): 21.5%
Compound 4: the middle estimate sits 0.5 percentage points below what was measured; the measured number falls inside the stated range.
By their numbers in this assay, from the lowest: compounds 1, 3, 2 and 4 (each within the scatter of the next).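

In this assay, 2-methylfuran-3-yl in place of 2-chloro-5-methoxyphenyl now has a second reading, a number 5 percentage points higher from compound 3 to compound 4 (within the scatter), and the two readings agree within the scatter: the same change on two cores in this assay, a number 5.7 percentage points higher (within the scatter) from compound 1 to compound 2 and a number 5 percentage points higher (within the scatter) from compound 3 to compound 4, 0.7 percentage points apart, within the scatter of two such steps. Hydrogen in place of methoxy on an aromatic carbon also has a second reading, a number 1.4 percentage points higher from compound 2 to compound 4 (within the scatter), and these two readings agree in the same way: the same change on two cores in this assay, a number 2.1 percentage points higher (within the scatter) from compound 1 to compound 3 and a number 1.4 percentage points higher (within the scatter) from compound 2 to compound 4, 0.7 percentage points apart, within the scatter of two such steps. Each exchange therefore gives a step within the scatter on both cores, and neither is shown to move the number beyond it.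

As far as these compounds go, it remains open whether any group on this aromatic carbon of the five-membered ring with 3 nitrogen would give a step beyond the scatter, for example an amine or a carboxylic acid. The compounds shown also leave open whether these steps would hold at another dose or a different time.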